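The source may hold more compounds than are shown below. What is called first, only, known or untested is meant among the compounds shown, and "the series" means these compounds.

Of the compounds shown here, three have so far been measured in a functional assay on CHO-K1 cells for agonist activity at Glucose-dependent insulinotropic receptor (Homo sapiens), read by HTRF and cAMP accumulation, with a stated time of 30 min; on this read-out lower numbers stand for smaller maximal responses and higher numbers for larger maximal responses. Compound 1 `CC(C)(C)OC(=O)N1CCC(CCCNc2ccc3c(c2)NNS3(=O)=O)CC1` gives 99%, and compound 2 `CC(C)(C)OC(=O)N1CCC(CCCNc2ccc3c(c2)C(=O)CO3)CC1` gives 95%. Compound 3 `COC(=O)c1cnc(N2CCC(CCCNc3ccc4c(c3)OCC4=O)CC2)nc1` gives 85%, the lowest of the three numbers. The value of compound 2 differs from that of compound 3 by an amount within the usual scatter, so the two cannot be told apart, whereas compound 1 stands beyond the scatter above compound 3. Among the measured compounds shown here, no pair among the three differs in only one place, so no single structural step can yet be tied to a change in the maximal response.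

Compound 4 `CC(C)c1nsc(N2CCC(CCCNc3ccc4c(c3)OCC4=O)CC2)n1` has not yet been measured. It differs from compound 3 in one place: 3-isopropyl-1,2,4-thiadiazol-5-yl in place of 5-(methoxycarbonyl)pyrimidin-2-yl on an amine nitrogen in a ring. Because compound 3 itself gives 85%, the expectation is that compound 4 will also reach a large maximal response. The step of a number 5 percentage points higher from compound 3 to compound 4 (within the scatter) is expected to be small, with no change beyond the scatter in either direction. Compound 4 is therefore estimated to give 90%, within a range from 75% to 102%.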

Compound 4, largest response reached (Emax), in percent of the reference or control that the assay uses: 10%
Beside the measured number, compound 4's estimate is 80 percentage points above it, and the stated range ends above it.
By their numbers in this assay, from the lowest: compound 4; then compounds 3, 2 and 1 (each within the scatter of the next, the first and the last beyond it).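

Putting 3-isopropyl-1,2,4-thiadiazol-5-yl in place of 5-(methoxycarbonyl)pyrimidin-2-yl on the amine nitrogen in the ring gives a number 75 percentage points lower from compound 3 to compound 4 (beyond the scatter) in this assay and so ties a large change in maximal response to this one place. Among the compounds shown here, no pair among the earlier compounds differed in only one place, so they could not show that the group on this nitrogen can decide whether most of the response is kept or lost. The step changes several things together: a six-membered aromatic ring with 2 hetero atoms and its methoxycarbonyl group leave, while a five-membered aromatic ring with 3 hetero atoms, including sulfur, and an isopropyl group enter.

Nothing available here accounts for the size of this change.

The compounds shown leave open whether the loss follows the change of ring or the loss of the methoxycarbonyl group, and a pyrimidin-2-yl ring carrying a carboxylic acid or a nitrile at the same ring position, or a 1,2,4-thiadiazol-5-yl ring carrying a methoxycarbonyl group, would help separate the two.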